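A few compounds are considered here, and "the series" means these few. Any claim that something is new, unique, unknown or untested is made for them only; others in the source may bear on it.

Of the compounds shown here, three that share one core have so far been measured in an assay on isolated protein (Bos taurus) for inhibition of geranylgeranyl transferase type-1 subunit beta (Homo sapiens); on this read-out higher numbers stand for weaker inhibition and lower numbers for stronger inhibition. Compound 3 `Cn1cncc1C(OCc1ccc(C#N)cc1-c1cccc(OC(F)(F)F)c1)c1ccc(C#N)nc1` carries a 3-(trifluoromethoxy)phenyl group and gives 990 nM in this assay, the lowest of the two readable numbers. Compound 1 `Cn1cncc1C(OCc1ccc(C#N)cc1-c1ccc(F)c(Cl)c1)c1ccc(C#N)nc1` carries 3-chloro-4-fluorophenyl at the same place and gives 8600 nM in this assay, and the step between them is an 8.7-fold lower number from compound 1 to compound 3 (0.94 log units; beyond the scatter). Compound 2 `Cn1cncc1C(OCc1ccc(C#N)cc1-c1cccc2ccccc12)c1ccc(C#N)nc1` carries naphthalen-1-yl and gives > 10 nM in this assay, which is a limit of the assay and not a number. Because of that limit of > 10 nM in this assay, at which 1 of the 3 values shown sits, the steps a step that the limit leaves unreadable from compound 1 to compound 2 and a step that the limit leaves unreadable from compound 2 to compound 3 cannot be read.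

Compound 4 `Cn1cncc1C(OCc1ccc(C#N)cc1-c1cc(Cl)cc(Cl)c1)c1ccc(C#N)nc1` has not yet been measured. It differs from compound 3 in one place: 3,5-dichlorophenyl in place of 3-(trifluoromethoxy)phenyl on an aromatic carbon. Among the measured compounds shown here, only one measured step, the one with two readable numbers, bears on this change, and it shows that exchanging one substituted phenyl for another at this position can shift the number by a modest amount. Compound 4 is therefore expected to give about 1500 nM in this assay, with a range from 300 nM to 8000 nM. The step this estimate implies, a 1.5-fold higher number from compound 3 to compound 4 (0.18 log units; within the scatter), is expected to fall within the usual scatter, with no clear direction.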

Compound 4, half-maximal inhibitory concentration: 960 nM
Estimate against measurement, compound 4: 1.6-fold (0.19 log units) above; the measured number falls inside the stated range.
By their numbers in this assay, from the lowest: compounds 4 and 3 (each within the scatter of the next); then compound 1.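

Exchanging 3-(trifluoromethoxy)phenyl for 3,5-dichlorophenyl at this place gives a 1.0-fold lower number from compound 3 to compound 4 (0.01 log units; within the scatter) in this assay, so these two groups cannot be told apart here, even though one holds oxygen and fluorine and the other holds chlorine. The step from the remaining readable group is different: 3,5-dichlorophenyl in place of 3-chloro-4-fluorophenyl gives a 9.0-fold lower number from compound 1 to compound 4 (0.95 log units; beyond the scatter). Among the compounds shown here, with this second readable replacement of the group in compound 1, it is now 3-chloro-4-fluorophenyl that stands apart among the three readable compounds, so the one earlier step did not merely reflect something particular to 3-(trifluoromethoxy)phenyl.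

The steps that involve compound 2, with its naphthalen-1-yl group, cannot be read, because the value of compound 2 is a limit of the assay and not a number: the limit of > 10 nM in this assay, at which 1 of the 4 values shown sits.

It also remains open how this position would respond to an unsubstituted phenyl, or to a phenyl carrying an amine or a carboxylic acid, since every readable group shown here is a phenyl bearing halogen or trifluoromethoxy.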